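Adding Chloro to a Sparsely Measured Series

The source may hold more compounds than are shown below. What is called first, only, known or untested is meant among the compounds shown, and "the series" means these compounds.

For the measured compounds named here, only two compounds have been examined so far in a physicochemical assay for solubility, read by HPLC, at pH 7.4; on this read-out higher numbers stand for higher solubility and lower numbers for lower solubility. Going by the values given here, in that assay, compound 1 `Cc1[nH]c2ccccc2c(=O)c1Cc1ccccc1` gives 10000 nM, the only actual number available. Compound 2 `Cc1[nH]c2ccccc2c(=O)c1/C=C/c1cccc([N+](=O)[O-])c1` is reported only as a limit, < 2000 nM, and not as a number.

The next compound to be measured, compound 3 `Cc1[nH]c2ccc(Cl)cc2c(=O)c1Cc1ccccc1`, keeps the core of compound 1 and changes it in one place (chloro in place of hydrogen on an aromatic carbon). It has chloro in place of hydrogen on an aromatic carbon, and the benzyl-bearing remainder of the structure stays as it was.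

Among the compounds with values here, no measured pair shows what this replacement does, so the forecast is a judgement with wide margins. A moderate step downward in this assay is expected, starting from compound 1 at 10000 nM, and a result within the usual scatter cannot be ruled out. The expected change is a 2.5-fold lower number from compound 1 to compound 3 (0.40 log units; beyond the scatter). The assay may also report only a limit for compound 3. Compound 3 is estimated to read about 4000 nM, within an expected range of 2000 nM to 9000 nM.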

Compound 3, solubility: < 2000 nM
Compound 3: only a limit was reported (the forecaster's own chance of this, stated with the estimate: 30%); middle value at least 2.0-fold (0.30 log units) away from the limit.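

For the compounds shown here, this is the first pair that differ in one place, and it gives the replacement a direction: chloro in place of hydrogen on an aromatic carbon of the core of compound 1 gives an at least 5.0-fold lower number from compound 1 to compound 3 (0.69 log units; beyond the scatter) in this assay. For compound 3 the reading is a limit, < 2000 nM, and not a number. The step is thus a minimum and not a measured size, and the reading stands at a limit shared within this small set: the limit of < 2000 nM in this assay, at which 2 of the 3 values shown sit.

The compounds shown leave open how large the step really is, since no number for compound 3 is available, and they say nothing about why the reading moves, as the step is a single observation at one place on the ring. They also leave open whether the same direction holds for other groups on this aromatic carbon, such as a carboxylic acid, an amine or a methoxy group, and whether chloro at another carbon of the same six-membered ring would give a step of similar size.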